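Fluorosulfonyl on the distal ring of a dihydrotriazine series

A few compounds are considered here, and "the series" means these few. Any claim that something is new, unique, unknown or untested is made for them only; others in the source may bear on it.

Measured so far:
compound 1 `CC1(C)N=C(N)N=C(N)N1c1ccc(CCc2ccccc2)cc1` — 7.89
compound 2 `CC1(C)N=C(N)N=C(N)N1c1ccc(OCc2ccc(COc3ccc(S(=O)(=O)F)cc3)cc2)c(Cl)c1` — 6.82

In an assay on isolated protein for inhibition of Dihydrofolate reductase (Mus musculus) (a lower number here means a less potent compound, a higher number a more potent compound, by a factor of ten per unit of this negative logarithm), compound 1 stands highest of the two numbers, and compound 2 lies a gap beyond the scatter lower. For the measured compounds named here, no pair of measured compounds differs in one place only, so no step is known. Compound 3 `CC1(C)N=C(N)N=C(N)N1c1ccc(CCc2ccc(S(=O)(=O)F)cc2)cc1` differs from compound 1 by fluorosulfonyl in place of hydrogen on an aromatic carbon. Compound 2 carries the same group on a larger, differently linked scaffold, which gives no clean guide. The expected step of a number 0.29 log units lower from compound 1 to compound 3 (within the scatter) is small, downward or none beyond the scatter. Compound 3 is estimated at 7.6, range 6.9 to 8.3.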

Compound 3, logarithm of the reciprocal of the active concentration, log(1/C): 7.41
For compound 3 the middle estimate is 0.19 log units above the measured one; the range from low to high includes it.
By their numbers in this assay, from the lowest: compound 2; then compound 3; then compound 1.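

In this assay, for the compounds shown here, fluorosulfonyl in place of hydrogen on an aromatic carbon, para to a large group, gives a number 0.48 log units lower from compound 1 to compound 3 (beyond the scatter) as the first single-place step. This position therefore accepts fluorosulfonyl at a modest cost in potency. Nothing available accounts for the loss.

The compounds shown leave open whether the loss is specific to fluorosulfonyl or would also follow from another group on this carbon, such as fluorine, methyl or a sulfonamide. Also open, on these data alone, is what fluorosulfonyl contributes on the larger scaffold of compound 2, which has no unsubstituted partner here.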